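A few compounds are considered here, and "the series" means these few. Any claim that something is new, unique, unknown or untested is made for them only; others in the source may bear on it.

Measured in a functional assay on A549 cells (Homo sapiens) for antiproliferative activity, read by MTT assay, with a stated time of 48 h; a higher number here means a weaker inhibitor, a lower number a stronger inhibitor:
compound 1 `O=C(/C=C/c1ccc(/C=C/C(=O)c2cccc(Cl)c2)o1)NO` gives 18900 nM
compound 2 `O=C(/C=C/c1ccc(/C=C/C(=O)c2ccc(Cl)cc2)o1)NO` gives 98100 nM

Compound 1 has the lowest of these two numbers, which makes it the stronger inhibitor of the pair. Compound 3 `O=C(/C=C/c1ccc(/C=C/C(=O)c2cc(Cl)ccc2Cl)o1)NO` has not yet been measured. It differs from compound 1 by one change: chloro in place of hydrogen on an aromatic carbon. In words, a chloro group takes the place of a hydrogen on an aromatic carbon, ortho to a large group and para to a chloro group.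

Among the compounds with values here, only one measured step bears on this: a 5.2-fold higher number from compound 1 to compound 2 (0.72 log units; beyond the scatter). It is modest but beyond the scatter. Within the data shown here, that step moves a chloro group rather than adding one, so it shows only that the number in this assay can shift with a change on this ring. Among the measured compounds shown here, no measured pair shows what a second chloro group does, so the direction remains uncertain. A step of modest size is expected, leaning slightly towards a higher number and a weaker inhibitor. The estimated step is a 1.6-fold higher number from compound 1 to compound 3 (0.20 log units; within the scatter). For compound 3 the expected value is 30000 nM, with an estimated range of 9000 nM to 90000 nM.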

Compound 3, half-maximal inhibitory concentration: 27100 nM
Compound 3: the middle estimate sits 1.1-fold (0.04 log units) above what was measured; measured number inside the range.
By their numbers in this assay, from the lowest: compounds 1 and 3 (each within the scatter of the next); then compound 2.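

In this assay, a chloro group placed on an aromatic carbon, ortho to a large group and para to a chloro group, gives a 1.4-fold higher number from compound 1 to compound 3 (0.16 log units; within the scatter) and so leaves compound 1 and compound 3 inseparable. Within the data shown here, this is the first sign of what a second chloro group does on this ring: at this position it is tolerated, with no effect that can be read in this assay, whereas moving the single chloro group to another place on the ring gave a 5.2-fold higher number from compound 1 to compound 2 (0.72 log units; beyond the scatter), a step beyond the scatter. No measurement shown here offers an explanation for this tolerance.

The compounds shown leave open whether this position would tolerate other groups as well, such as a methoxy group, an amine or a carboxylic acid, since chloro is the only group seen there. They also leave open what a chloro group at this position does on its own, without the chloro group that compound 1 already carries, and whether the same tolerance would hold on the ring of compound 2.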